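Removing a Methylsulfonyl Group from a Weak Antiproliferative Amide

The source may report more compounds than this note shows. Statements on the series, on what has been measured and on what is new or still open speak of the compounds shown alone.

Measured so far:
Compound 1 `O=C(Nc1ccc(Cl)c(-c2nnc3c(Cl)cccn23)c1)c1cccnc1` gives > 100000 nM in a functional assay on U-251 cells (Homo sapiens) for antiproliferative activity, read by MTT assay, with a stated time of 72 h; on this read-out lower numbers stand for stronger inhibition and higher numbers for weaker inhibition; this is a limit of the assay, not a number.
Compound 2 `CS(=O)(=O)c1ccc(C(=O)Nc2ccc(Cl)c(-c3nnc4c(Cl)cccn34)c2)c(Cl)c1` gives 44600 nM in this assay.

Within the data shown here, compound 2 therefore stands as the only compound with an actual number in this assay. The value of compound 1 is the limit of > 100000 nM in this assay, at which 1 of the 2 values shown sits.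

Compound 3 `O=C(Nc1ccc(Cl)c(-c2nnc3c(Cl)cccn23)c1)c1ccccc1Cl` has not been measured. It differs from compound 2 by hydrogen in place of methylsulfonyl on an aromatic carbon. Among the measured compounds shown here, no pair of measured compounds differs in a single place, so the size of such a step is not yet known from these data. Since compound 2 already sits at the weak end with 44600 nM, compound 3 is expected to show a further small loss, or nothing beyond the scatter. Compound 3 is estimated at 70000 nM, ranging from 20000 nM to 200000 nM. That expectation corresponds to a step of a 1.6-fold higher number from compound 2 to compound 3 (0.20 log units; within the scatter).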

Compound 3, half-maximal inhibitory concentration: > 100000 nM
Compound 3 was reported as a limit (the forecaster's own chance of this, stated with the estimate: 50%); at least 1.4-fold (0.15 log units) between middle value and limit.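

In this assay, among these compounds, this is the first step that can be read at this position: putting hydrogen in place of methylsulfonyl on the aromatic carbon gives an at least 2.2-fold higher number from compound 2 to compound 3 (0.35 log units; beyond the scatter). Compound 3 gives > 100000 nM, which is a limit of the assay and not a number. Going by these compounds, the methylsulfonyl group therefore counts for something here, even though compound 2, which carries it, is itself weak, and the full size of the step remains unknown.

The step between compound 1 and compound 3 cannot be read, since the compounds shown mostly sit at the same ceiling: the limit of > 100000 nM in this assay, at which 2 of the 3 values shown sit. On these data alone, whether an amine or a carboxylic acid on this aromatic carbon would match or improve on compound 2 stays open, as does whether anything here depends on the sulfur group specifically.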